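A Larger Ether Group on a Myeloperoxidase Inhibitor

The source may report more compounds than this note shows. Statements on the series, on what has been measured and on what is new or still open speak of the compounds shown alone.

Measured in an assay on isolated protein for inhibition of Myeloperoxidase (Homo sapiens), with a stated time of 10 min; a higher number here means a weaker inhibitor, a lower number a stronger inhibitor:
compound 1 `Nc1cc(Cc2ccn(Cc3cccc(Oc4ccccc4)c3)n2)c2nn[nH]c2n1`: 44 nM
compound 2 `Nc1cc(Cc2ccn(-c3ccc(F)cc3)n2)c2nn[nH]c2n1`: 53 nM

Compound 1 has the lower of the two numbers in this assay, but its gap to compound 2 is within the scatter, so the two cannot be separated on this evidence. The next compound, compound 3 `Nc1cc(Cc2ccn(Cc3cccc(Oc4cccc5c4CNC5)c3)n2)c2nn[nH]c2n1`, is still to be measured in this assay. It differs from compound 1 in one place: a group of 9 heavy atoms (8 carbon, 1 nitrogen; one five-membered non-aromatic ring with 1 hetero atom, one six-membered aromatic ring of carbon only) in place of a group of 6 heavy atoms (6 carbon; one six-membered aromatic ring of carbon only), on an oxygen on an aromatic ring. No comparable change occurs between the two measured compounds, so nothing among them shows what this kind of replacement does. The expectation is a small step, either none beyond the scatter or a modest move toward a lower number. The estimate for compound 3 in this assay is 30 nM, with a range from 10 nM to 100 nM. This estimate amounts to an expected step of a 1.5-fold lower number from compound 1 to compound 3 (0.17 log units; within the scatter).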

Compound 3, half-maximal inhibitory concentration: 26 nM
Beside the measured number, compound 3's estimate is 1.2-fold (0.06 log units) above it; low and high end bracket the measured number.
By their numbers in this assay, from the lowest: compounds 3, 1 and 2 (each within the scatter of the next, the first and the last beyond it).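

Replacing the phenyl on the oxygen with the larger group, which adds a five-membered non-aromatic ring containing a nitrogen, gives a 1.7-fold lower number from compound 1 to compound 3 (0.23 log units; within the scatter) in this assay. That step lies within the usual scatter, so the two compounds cannot be told apart, but it does show that this place on the molecule can carry a clearly larger group, with a hydrogen-bond donor and acceptor, and still give a value in the same range. No separate measurement bears on why the numbers came out this way.

With only this one replacement shown at the oxygen, the part played by the ring nitrogen remains unknown. An all-carbon five-membered ring in its place would test that directly, while a carboxylic acid on the phenyl would show how a different kind of group fares here.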